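The source may report more compounds than this note shows. Statements on the series, on what has been measured and on what is new or still open speak of the compounds shown alone.

In a functional assay on the whole organism with Rattus norvegicus as the target (on this read-out lower numbers stand for an effect already at smaller amounts and higher numbers for an effect only at larger amounts of compound), compound 1 `CCOC(=O)C(=O)Nc1cccc(NC)c1C#N` gives 0.1 mg/kg, compound 2 `CCCNc1cccc(NC(=O)C(=O)OCC)c1C#N` gives 0.7 mg/kg and compound 3 `CCCCNc1cccc(NC(=O)C(=O)OCC)c1C#N` gives 0.3 mg/kg, which places compound 3 between the other two. The next structure, compound 4 `CCOC(=O)C(=O)Nc1cccc(C)c1C#N`, departs from compound 3 as follows: methyl in place of butylamino on an aromatic carbon. The measured steps, a 7.0-fold higher number from compound 1 to compound 2 (0.85 log units; beyond the scatter), a 3.0-fold higher number from compound 1 to compound 3 (0.48 log units; beyond the scatter) and a 2.3-fold lower number from compound 2 to compound 3 (0.37 log units; beyond the scatter), are all modest and only vary the chain on the nitrogen. None of them removes that nitrogen, so they offer no direction for this change, and no shift clearly beyond the scatter is expected. The expected step is a 1.3-fold higher number from compound 3 to compound 4 (0.12 log units; within the scatter). The estimated value for compound 4 is 0.4 mg/kg, within an expected range from 0.08 mg/kg to 2 mg/kg.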

Compound 4, dose for half-maximal effect: 4.6 mg/kg
Beside the measured number, compound 4's estimate is 12-fold (1.06 log units) below it; measured number above the stated range.
By their numbers in this assay, from the lowest: compound 1; then compound 3; then compound 2; then compound 4.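

In this assay this aromatic carbon proves sensitive to losing the nitrogen: methyl in place of butylamino gives a 15-fold higher number from compound 3 to compound 4 (1.19 log units; beyond the scatter), methyl in place of propylamino gives a 6.6-fold higher number from compound 2 to compound 4 (0.82 log units; beyond the scatter) and methyl in place of methylamino gives a 46-fold higher number from compound 1 to compound 4 (1.66 log units; beyond the scatter). Each of the three compounds with an alkylamino group here therefore has a lower number than compound 4, whichever chain it carries. No measured evidence accounts for this shift. As far as these compounds go, whether an unsubstituted amine or a hydroxyl group on this carbon would also keep the number low remains open, as does the effect of a chain longer than butyl on the nitrogen.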